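The compounds below may be only part of what the source reports. "The series", "measured", "known", "first", "only" and "open" are said of these compounds alone.

In a functional assay on A549 cells (Homo sapiens) for cytotoxicity, read by MTT assay, with a stated time of 72 h (on this read-out lower numbers stand for stronger inhibition and higher numbers for weaker inhibition), compound 1 `CCN(CC)Cc1ccc2nc(NC(=O)N/N=C/c3cn(Cc4ccc(Cl)cc4Cl)c4ccccc34)sc2c1` gives 1900 nM and compound 2 `CCN(CC)Cc1ccc2nc(NC(=O)N/N=C/c3cn(Cc4ccc(C)cc4)c4ccccc34)sc2c1` gives 1510 nM, so compound 2 stands level with compound 1 within the usual scatter. Compound 3 `CCN(CC)Cc1ccc2nc(NC(=O)N/N=C/c3c[nH]c4ccccc34)sc2c1` has hydrogen in place of 4-methylbenzyl on an aromatic nitrogen. For the measured compounds named here, the only measured step, a 1.3-fold lower number from compound 1 to compound 2 (0.10 log units; within the scatter), changed the ring of this substituent without removing it, so it offers only limited guidance, and no measured compound lacks the substituent. A modest shift toward weaker inhibition is tentatively expected, namely a 2.0-fold higher number from compound 2 to compound 3 (0.30 log units; within the scatter). For compound 3 the estimated value is 3000 nM, with an expected range of 1000 nM to 10000 nM.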

Compound 3, half-maximal inhibitory concentration: 3300 nM
The estimate for compound 3 lay 1.1-fold (0.04 log units) below the measured number; low and high end bracket the measured number.
By their numbers in this assay, from the lowest: compounds 2, 1 and 3 (each within the scatter of the next, the first and the last beyond it).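

Taking the whole benzyl group off the aromatic nitrogen gives a 2.2-fold higher number from compound 2 to compound 3 (0.34 log units; beyond the scatter) and, for the other benzyl group, a 1.7-fold higher number from compound 1 to compound 3 (0.24 log units; within the scatter) as a second reading. Compound 3, with only hydrogen there, thus keeps its cytotoxicity: 4-methylbenzyl brings a modest gain over hydrogen, while 2,4-dichlorobenzyl brings none beyond the scatter. No measurement here explains this difference.

As far as these compounds go, whether a small methyl group or a longer chain such as butyl on this nitrogen would fall nearer compound 3 or compound 2 stays open. So does the effect of an amine on the benzyl ring.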